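Notes on the cyano-for-methyl change on the fused ring

This account rests on a few compounds, and the source may have more. Where it says the series, first, only, none or still open, it means among the compounds named here.

Measured in an assay on cells for inhibition of cytochrome P450 11B2, mitochondrial (Homo sapiens), read by HTRF, with stated times of 1 h and 3 h; on this read-out lower numbers stand for stronger inhibition and higher numbers for weaker inhibition:
- compound 1, `Fc1cncc(-n2ncc3cc(F)ccc32)c1`: 456 nM
- compound 2, `Cc1ccc2c(cnn2-c2cncc(C(C)(C)O)c2)c1`: 97.9 nM

Compound 2 gives the lowest of the two numbers in this assay. Compound 1 gives a higher number, and the gap between the two lies beyond the scatter. These two compounds differ in more than one place, so only their values are set side by side here.

Compound 3, `CC(C)(O)c1cncc(-n2ncc3cc(C#N)ccc32)c1`, is not yet measured in this assay. It differs from compound 2 by cyano in place of methyl on an aromatic carbon. Among the measured compounds shown here, no measured pair shows this change, so the size of the step can only be estimated from compound 2 alone. No step beyond the scatter is expected in either direction. The expected step is a 1.4-fold lower number from compound 2 to compound 3 (0.15 log units; within the scatter). Compound 3 is estimated to give 70 nM, with a range from 20 nM to 250 nM.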

Compound 3, half-maximal inhibitory concentration: 1160 nM
The estimate for compound 3 lay 17-fold (1.22 log units) below the measured number; measured number above the stated range.
By their numbers in this assay, from the lowest: compound 2; then compound 1; then compound 3.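

In this assay, among the compounds shown here, cyano in place of methyl on this aromatic carbon gives a 12-fold higher number from compound 2 to compound 3 (1.07 log units; beyond the scatter), the first single-place comparison. The position is therefore not indifferent to its substituent: with the rest of the structure shared, inhibition weakens markedly when methyl gives way to cyano at this carbon of the fused system. No measurement at hand accounts for the step.

For the compounds shown here, the single pair leaves open whether the weakening is particular to cyano or whether other replacements for methyl, such as chloro, methoxy or an amine, would also weaken inhibition here. Going by these compounds alone, it also leaves open whether a step of this size would recur if the group on the other aromatic ring were something other than the one shared by compound 2 and compound 3.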